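Aryl urea series: the 4-chlorophenyl step

The source may report more compounds than this note shows. Statements on the series, on what has been measured and on what is new or still open speak of the compounds shown alone.

Values in a functional assay on HeLa cells (Homo sapiens) for inhibition, read by MTT assay, with a stated time of 72 h (a lower number here means a stronger inhibitor, a higher number a weaker inhibitor), so far:
- compound 1 `COc1cc(NC(C)CCCNC(=O)Nc2cccc(Cl)c2)c2ncccc2c1` gives 17000 nM
- compound 2 `COc1cc(NC(C)CCCNC(=O)Nc2ccc(Br)cc2)c2ncccc2c1` gives 20000 nM
- compound 3 `COc1cc(NC(C)CCCNC(=O)Nc2cccc(C(F)(F)F)c2)c2ncccc2c1` gives 14000 nM

Compound 3 is not separated from the other two compounds on these numbers. Its steps (a 1.2-fold lower number from compound 1 to compound 3 (0.08 log units; within the scatter) and a 1.4-fold lower number from compound 2 to compound 3 (0.15 log units; within the scatter)) both lie within the scatter.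

The next compound is compound 4 `COc1cc(NC(C)CCCNC(=O)Nc2ccc(Cl)cc2)c2ncccc2c1`, in which 4-chlorophenyl stands in place of 3-(trifluoromethyl)phenyl on an amide-type nitrogen (4-chlorophenyl in place of 3-(trifluoromethyl)phenyl on an amide-type nitrogen). The shared core and chain stay as they are.

Within the data shown here, three measured steps bear on this change, and each exchanges only the aryl group on that nitrogen. The two above are joined by a third (a 1.2-fold higher number from compound 1 to compound 2 (0.07 log units; within the scatter)), which also lies within the scatter. Among the measured compounds shown here, no measured step in this small set goes against that picture, though none of the three compounds carries the 4-chlorophenyl group itself. The closest measured groups are the 3-chlorophenyl of compound 1 and the 4-bromophenyl of compound 2.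

No step beyond the scatter is therefore expected in this assay, and the expected step is small (a 1.2-fold higher number from compound 3 to compound 4 (0.08 log units; within the scatter)). For compound 4 the estimated value is 17000 nM, with an expected range from 10000 nM to 28000 nM.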

Compound 4, half-maximal inhibitory concentration: 18000 nM
The estimate for compound 4 lay 1.1-fold (0.02 log units) below the measured number; the range from low to high includes it.
By their numbers in this assay, from the lowest: compounds 3, 1, 4 and 2 (each within the scatter of the next).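

In this assay, the 4-chlorophenyl group on the amide-type nitrogen adds a direct halogen comparison to the series: chloro in place of bromo on an aromatic carbon stays within the scatter (a 1.1-fold lower number from compound 2 to compound 4 (0.05 log units; within the scatter)). Among these compounds, compound 4 also gives the first comparison of one halogen on the two printed ring locations, 4-chlorophenyl against 3-chlorophenyl, and that step also stays within the scatter (a 1.1-fold higher number from compound 1 to compound 4 (0.02 log units; within the scatter)), as does the exchange for 3-(trifluoromethyl)phenyl (a 1.3-fold higher number from compound 3 to compound 4 (0.11 log units; within the scatter)). Across these four compounds, neither the halogen, nor the location of chloro, nor chloro against trifluoromethyl separates one compound from another in this assay, and nothing measured here offers an explanation for that.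

Every aryl group shown carries a single halogen or trifluoromethyl substituent, so it remains open whether an aryl group bearing an amine or a carboxylic acid would step beyond the scatter. As far as these compounds go, it also remains open whether a longer chain between the shared core and the urea would separate from these four compounds.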